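Salicylate diesters, rat plasma stability: compound 4

The source may report more compounds than this note shows. Statements on the series, on what has been measured and on what is new or still open speak of the compounds shown alone.

In an ADME assay on a cell-free system (plasma, Homo sapiens) for metabolic stability, with Plasma (Rattus norvegicus) as the target, read by HPLC, at pH 7.4 (a lower number here means that the compound disappears faster, a higher number that the compound lasts longer), compound 1 `CC(=O)Oc1ccccc1C(=O)O[C@H]1CO[C@H]2[C@@H]1OC[C@H]2OC(=O)c1cccc(O)c1` gives 0.015 h, compound 2 `CCC(=O)O[C@@H]1CO[C@H]2[C@@H]1OC[C@@H]2OC(=O)c1ccccc1OC(C)=O` gives 0.011 h, and compound 3 `CC(=O)Nc1cccc(C(=O)O[C@@H]2CO[C@H]3[C@@H]2OC[C@@H]3OC(=O)c2ccccc2OC(C)=O)c1` gives 0.0583 h, the highest of the three. The measured steps are a 1.4-fold lower number from compound 1 to compound 2 (0.13 log units; within the scatter), a 3.9-fold higher number from compound 1 to compound 3 (0.59 log units; beyond the scatter) and a 5.3-fold higher number from compound 2 to compound 3 (0.72 log units; beyond the scatter). Compound 4 `CC(=O)Oc1ccccc1C(=O)O[C@H]1CO[C@H]2[C@@H]1OC[C@H]2OC(=O)c1cccc(CO[N+](=O)[O-])c1` carries the change ((nitrooxy)methyl in place of acetamido on an aromatic carbon). Among the measured compounds shown here, both steps beyond the scatter led to compound 3 with acetamido arriving, and acetamido now leaves; no measured step covers (nitrooxy)methyl. The number for compound 4 is therefore expected to fall back toward compound 1 in this assay. The expected step is a 2.9-fold lower number from compound 3 to compound 4 (0.46 log units; beyond the scatter). Compound 4 is estimated at 0.02 h, within 0.008 h to 0.06 h.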

Compound 4, half-life: 0.045 h
Estimate against measurement, compound 4: 2.3-fold (0.35 log units) below, within the range that was stated.
By their numbers in this assay, from the lowest: compounds 2 and 1 (each within the scatter of the next); then compounds 4 and 3 (each within the scatter of the next).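

In this assay the higher level at this aromatic carbon does not depend on acetamido: replacing it with (nitrooxy)methyl gives a 1.3-fold lower number from compound 3 to compound 4 (0.11 log units; within the scatter) as the step. In place of hydroxy, (nitrooxy)methyl gives a 3.0-fold higher number from compound 1 to compound 4 (0.48 log units; beyond the scatter) as the step, and 3-((nitrooxy)methyl)phenyl in place of ethyl gives a 4.1-fold higher number from compound 2 to compound 4 (0.61 log units; beyond the scatter) as the step, so the rise seen with acetamido is not unique to it. No measurement shown bears on the reason for this result. Still open, as far as these compounds go, is whether an amine or a carboxylic acid on this aromatic carbon would stay level with compound 3 and compound 4 or fall back toward compound 1.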